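A few compounds are considered here, and "the series" means these few. Any claim that something is new, unique, unknown or untested is made for them only; others in the source may bear on it.

In a functional assay on HepG2 cells (Homo sapiens) for antiproliferative activity, read by MTT assay, with a stated time of 48 h (a lower number here means a stronger inhibitor, a higher number a weaker inhibitor), the measured compounds are
Compound 1 `CC(=O)N1N=C(c2ccc3ccccc3c2)OC1c1ccccc1` at 2.11 ug/mL
Compound 2 `CC(=O)N1N=C(c2ccc3ccccc3c2)OC1c1ccc(C)cc1` at 2.26 ug/mL

For the measured compounds named here, compound 2 has only one measured neighbour on these numbers, and the two cannot be ranked. The next compound is compound 3 `CC(=O)N1N=C(c2ccc3ccccc3c2)OC1c1ccc(OCc2ccccc2)cc1` with benzyloxy in place of methyl on an aromatic carbon. Going by the values given here, the counted difference is benzyloxy in place of methyl on an aromatic carbon and it is the only change. Among the compounds with values here, one measured step bears on it, namely a 1.1-fold higher number from compound 1 to compound 2 (0.03 log units; within the scatter) which lies within the scatter and sits at the same aromatic carbon. Within the data shown here, that step involves only methyl, and no measured compound carries benzyloxy, so the evidence is thin. No shift beyond the scatter is expected in this assay but the uncertainty is wide. The expected step is a 1.1-fold higher number from compound 2 to compound 3 (0.04 log units; within the scatter) as an estimate. For compound 3 the estimated value is 2.5 ug/mL with 1 ug/mL to 6 ug/mL as the expected range.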

Compound 3, half-maximal inhibitory concentration: 3.38 ug/mL
Compound 3: the middle estimate sits 1.4-fold (0.13 log units) below what was measured; measured number inside the range.
By their numbers in this assay, from the lowest: compounds 1, 2 and 3 (each within the scatter of the next).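

In this assay the aromatic carbon that held methyl also accepts benzyloxy, a much larger group that brings a six-membered aromatic ring of carbon only and a hydrogen-bond acceptor, and the step stays small: a 1.5-fold higher number from compound 2 to compound 3 (0.17 log units; within the scatter), and measured against the unsubstituted parent, a 1.6-fold higher number from compound 1 to compound 3 (0.20 log units; within the scatter). Across hydrogen, methyl and benzyloxy at this carbon, then, no step leaves the scatter, and the three compounds cannot be ranked, although the size of the group now varies far more than compound 2 alone could show. No supporting measurement gives a reason for this flat response.

As far as these compounds go, whether an amine or a carboxylic acid at this carbon would give a step beyond the scatter remains open. The same holds for a change elsewhere, such as a longer chain in place of the acetyl group on the shared core.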